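Five-membered ring variation at the pyridine amide

The compounds below may be only part of what the source reports. "The series", "measured", "known", "first", "only" and "open" are said of these compounds alone.

In an assay on L cells for inhibition of Protein-serine O-palmitoleoyltransferase porcupine (Mus musculus), read by reporter gene assay, with a stated time of 24 h (on this read-out lower numbers stand for an effect already at smaller amounts and higher numbers for an effect only at larger amounts of compound), compound 3 `O=C(CSc1nc2c(c(=O)n1-c1ccccc1)SCC2)Nc1ccc(-c2cccs2)cn1` gives 0.3 nM, the lowest of the three numbers measured. Compound 2 `O=C(CSc1nc2c(c(=O)n1-c1ccccc1)SCC2)Nc1ccc(-c2ccsc2)cn1` gives 2 nM and compound 1 `O=C(CSc1nc2c(c(=O)n1-c1ccccc1)SCC2)Nc1ccc(-c2cncnc2)cn1` gives 5.5 nM in this assay. Compound 4 `O=C(CSc1nc2c(c(=O)n1-c1ccccc1)SCC2)Nc1ccc(-c2ccoc2)cn1` carries furan-3-yl in place of thiophen-2-yl on an aromatic carbon. Compound 2 carries thiophen-3-yl, the same point of attachment as furan-3-yl, so the step of a 6.7-fold lower number from compound 2 to compound 3 (0.82 log units; beyond the scatter) bears most directly; an 18-fold lower number from compound 1 to compound 3 (1.26 log units; beyond the scatter) and a 2.8-fold lower number from compound 1 to compound 2 (0.44 log units; beyond the scatter) set compound 3 apart from both others. Among the measured compounds shown here, no measured step exchanges sulfur for oxygen within this ring, and that part of the change is uncovered. The expected step is a rise back towards compound 2, namely for compound 4 a 10-fold higher number from compound 3 to compound 4 (1.00 log units; beyond the scatter). Compound 4 is estimated at 3 nM, range 0.8 nM to 12 nM.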

Compound 4, half-maximal effective concentration: 1.5 nM
The estimate for compound 4 lay 2.0-fold (0.30 log units) above the measured number; low and high end bracket the measured number.
By their numbers in this assay, from the lowest: compound 3; then compounds 4 and 2 (each within the scatter of the next); then compound 1.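

Furan-3-yl is the first ring with oxygen at this position, and with the point of attachment held, exchanging thiophen-3-yl for it gives no change beyond the scatter (a 1.3-fold lower number from compound 2 to compound 4 (0.12 log units; within the scatter)). The drop from pyrimidin-5-yl seen with the thiophenes also holds for furan-3-yl (a 3.7-fold lower number from compound 1 to compound 4 (0.56 log units; beyond the scatter)), while thiophen-2-yl stays apart (a 5.0-fold higher number from compound 3 to compound 4 (0.70 log units; beyond the scatter)). Nothing measured here accounts for these steps.

Open, as far as these compounds go, is whether furan-2-yl would match thiophen-2-yl, which would separate ring atom from point of attachment. Also open, from the compounds shown here alone, is how an amine or a carboxylic acid on the five-membered ring would read.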